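Methoxy for Ethyl on the Pyrimidine of Compound 3

This account rests on a few compounds, and the source may have more. Where it says the series, first, only, none or still open, it means among the compounds named here.

Measured so far:
compound 1 `CC(C)(C)OC(=O)N1CCC(CCCNc2ccc3c(c2)OCC3=O)CC1`: 66 nM
compound 2 `CC(C)(C)OC(=O)N1CCC(CCCNc2ccc3c(c2)C(=O)CCO3)CC1`: 351 nM
compound 3 `CCc1cnc(N2CCC(CCCNc3ccc4c(c3)OCC4=O)CC2)nc1`: 159 nM

In a functional assay on CHO-K1 cells for agonist activity at Glucose-dependent insulinotropic receptor (Mus musculus), read by HTRF and cAMP accumulation, with a stated time of 30 min (on this read-out lower numbers stand for an effect already at smaller amounts and higher numbers for an effect only at larger amounts of compound), compound 1 gives 66 nM, compound 2 gives 351 nM and compound 3 gives 159 nM. Compound 3 therefore stands second highest of the three numbers: its nearest neighbour is compound 2, which gives a higher number beyond the scatter, and its furthest is compound 1, which gives a lower number, also beyond the scatter.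

Going by the values given here, only one measured step changes a single site, and it is the one that leads to compound 3 itself: a 2.4-fold higher number from compound 1 to compound 3 (0.38 log units; beyond the scatter). It exchanges the whole group on the ring nitrogen and is of modest size.

Compound 4 `COc1cnc(N2CCC(CCCNc3ccc4c(c3)OCC4=O)CC2)nc1` differs from compound 3 in one place: methoxy in place of ethyl on an aromatic carbon. Among the compounds with values here, no measured pair varies the substituent on the pyrimidine while keeping the rest fixed, so the only guide is that exchanging the entire group on that nitrogen moved the number modestly. A change confined to one small substituent on that ring is expected to move it less, and the step of a 1.3-fold higher number from compound 3 to compound 4 (0.10 log units; within the scatter) is estimated to stay within the scatter. Compound 4 is accordingly expected to give about 200 nM, with a range from 80 nM to 500 nM.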

Compound 4, half-maximal effective concentration: 60 nM
Estimate against measurement, compound 4: 3.3-fold (0.52 log units) above; the whole stated range lies above it.
By their numbers in this assay, from the lowest: compounds 4 and 1 (each within the scatter of the next); then compound 3; then compound 2.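

In this assay, the group on this aromatic carbon proves to matter: with the same count of heavy atoms and one hydrogen-bond acceptor added, methoxy in place of ethyl gives a step beyond the scatter (a 2.7-fold lower number from compound 3 to compound 4 (0.42 log units; beyond the scatter)). Going by these compounds alone, the earlier compounds offered only an exchange of the entire group on the ring nitrogen, so this is the first measured pair to isolate a substituent on the pyrimidine. It also changes how that larger exchange reads: 5-ethylpyrimidin-2-yl in place of tert-butoxycarbonyl raised the number (a 2.4-fold higher number from compound 1 to compound 3 (0.38 log units; beyond the scatter)), whereas 5-methoxypyrimidin-2-yl in its place leaves it within the scatter (a 1.1-fold lower number from compound 1 to compound 4 (0.04 log units; within the scatter)), so the pyrimidine as such does not carry a cost in this assay. No supporting measurement bears on what lies behind the step.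

The compounds shown leave open how an ethoxy group, a chlorine atom, a hydroxyl group or an amine would behave on this same carbon. They also leave open whether the 5-methoxypyrimidin-2-yl group would give a comparable number on the core of compound 2.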